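Lengthening an alkyl chain on an aziridinylquinone carbamate

The source may hold more compounds than are shown below. What is called first, only, known or untested is meant among the compounds shown, and "the series" means these compounds.

Three compounds share one core. Going by the values given here, compound 1 `CCCC1=C(N2CC2)C(=O)C(C(COC(N)=O)OC)=C(N2CC2)C1=O` gives 5.01 in a functional assay on L1210 cells (Mus musculus), with a stated time of 1 days (on this read-out higher numbers stand for higher potency (the scale is a negative logarithm) and lower numbers for lower potency), compound 2 `CCCC1=C(N2CC2)C(=O)C(CCC)=C(N2CC2)C1=O` gives 4.32, and compound 3 `CCC1=C(N2CC2)C(=O)C(CCOC(N)=O)=C(N2CC2)C1=O` gives 5.98, the highest of the three, standing a number 0.69 log units lower from compound 1 to compound 2 (beyond the scatter) apart from neither, since the only one-place step measured is a number 0.69 log units lower from compound 1 to compound 2 (beyond the scatter), a change on the other ring substituent. Compound 4 `CCCC1=C(N2CC2)C(=O)C(CCOC(N)=O)=C(N2CC2)C1=O` differs from compound 3 by methyl in place of hydrogen on a saturated chain carbon, two bonds along the chain from a double-bonded ring carbon. Among the compounds with values here, no measured step tests this change; the one known step does not bear on it. The step from compound 3 to compound 4 is therefore expected to be a number 0.08 log units lower from compound 3 to compound 4 (within the scatter), not beyond the scatter. Compound 4 is estimated at 5.9, within 5.4 to 6.4.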

Compound 4, logarithm of the reciprocal of the active concentration, log(1/C): 4.9
Compound 4: the middle estimate sits 1.00 log units above what was measured, and the stated range ends above it.
By their numbers in this assay, from the lowest: compound 2; then compounds 4 and 1 (each within the scatter of the next); then compound 3.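

A single added methyl on this saturated chain carbon is enough to move the number, with a number 1.08 log units lower from compound 3 to compound 4 (beyond the scatter) in this assay for the change from ethyl to propyl. With propyl in place, carbamoyloxy in place of methyl still counts, with a number 0.58 log units higher from compound 2 to compound 4 (beyond the scatter) on that chain, while hydrogen in place of methoxy gives a number 0.11 log units lower from compound 1 to compound 4 (within the scatter) as its step. No evidence at hand accounts for these steps. On these data alone, whether a butyl chain would lower the number further stays open, as does whether a hydroxyl in place of carbamoyloxy would hold the gain.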